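Adding a cyano group to compound 1

The compounds below may be only part of what the source reports. "The series", "measured", "known", "first", "only" and "open" are said of these compounds alone.

Compound 1 `O=C1Nc2ccc(F)cc2C1=Cc1ccc(-c2cn(-c3ccccc3)nn2)cc1` gives 8120 nM
Compound 2 `O=C1Nc2ccc(F)cc2/C1=C/c1ccc(-c2cn(-c3cccc(Cl)c3)nn2)cc1` gives 10500 nM

Among the compounds with values here, in a functional assay on HT-29 cells (Homo sapiens) for inhibition, read by CCK-8 assay, with a stated time of 24 h (on this read-out lower numbers stand for stronger inhibition and higher numbers for weaker inhibition), compound 1 gives 8120 nM and compound 2 gives 10500 nM, and these two values lie within the usual scatter of each other, so compound 1 cannot be told apart from the only other compound measured so far. Compound 3 `N#Cc1ccccc1-n1cc(-c2ccc(C=C3C(=O)Nc4ccc(F)cc43)cc2)nn1` has not yet been measured. It keeps the core of compound 1 and carries cyano in place of hydrogen on an aromatic carbon, ortho to a large group, which turns phenyl to 2-cyanophenyl. Within the data shown here, no measured pair shows what such a change does, so no known step can be carried over. In this assay no step beyond the scatter is expected, and neither direction is favoured. The expected step is small, a 1.1-fold higher number from compound 1 to compound 3 (0.04 log units; within the scatter) in this estimate. For compound 3 the estimated value is 9000 nM, with an expected range from 3500 nM to 25000 nM.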

Compound 3, half-maximal inhibitory concentration: > 13900 nM
Compound 3 gave a limit, no number; the forecaster's own chance of this, stated with the estimate: 8%; middle value at least 1.5-fold (0.18 log units) from the limit.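

In this assay the result for compound 3 is a limit of the assay and not a number: the limit of > 13900 nM in this assay, at which 1 of the 3 values shown sits. Read against compound 1, this gives an at least 1.7-fold higher number from compound 1 to compound 3 (0.23 log units; that floor lies within the scatter), so only a floor on the step is known, and the true step may be no larger than that floor or may be much larger. Within the data shown here, what this adds is a first reading for this change: cyano in place of hydrogen on an aromatic carbon, ortho to a large group, turning phenyl to 2-cyanophenyl, gives no sign of stronger inhibition in this assay.

From the compounds shown here alone, how a smaller group such as fluorine, or an amine or a carboxylic acid, would fare on this same carbon stays open. So does whether cyano on another carbon of that ring would give the same result.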